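The compounds below may be only part of what the source reports. "The series", "measured", "known", "first", "only" and "open" are said of these compounds alone.

In a functional assay for antagonist activity at 5-hydroxytryptamine receptor 4 (Rattus norvegicus) (a higher number here means a more potent compound, by a factor of ten per unit of this negative logarithm, a lower number a less potent compound), compound 1, with the structure `COc1ccc(COc2cc(N)c(Cl)cc2C(=O)CCCCN2CCCCC2)cc1OC`, gives 8.5. Compound 2, `COc1cc(COc2cc(N)c(Cl)cc2C(=O)CCCCN2CCCCC2)cc(OC)c1`, differs from it only in the placement of the methoxy groups: 3,5-dimethoxyphenyl in place of 3,4-dimethoxyphenyl on a saturated chain carbon bound to an oxygen on an aromatic ring. The step of no change at the digits printed from compound 1 to compound 2 (within the scatter) shows that this swap leaves the read-out where it was, so compound 2 stands level with compound 1 in this assay; in this assay compound 2 gives 8.5. Compound 3, `CCCCN1CCC(CCC(=O)c2cc(Cl)c(N)cc2OCc2cc(OC)cc(OC)c2)CC1`, has not been measured. The change from compound 2 to compound 3 lies elsewhere in the molecule: 1-butylpiperidin-4-yl in place of 2-(piperidin-1-yl)ethyl on a saturated chain carbon, two bonds along the chain from a carbonyl carbon. Among the measured compounds shown here, the single measured step concerns the dimethoxyphenyl group and does not touch the amine end of the chain, so no measured step bears directly on this change; it says only that one part of the shared core tolerates a rearrangement without loss. With nothing to lean on for the amine part, the expectation for compound 3 in this assay is at most a modest shift, a number 0.30 log units lower from compound 2 to compound 3 (within the scatter), carrying a wide range. Compound 3 is therefore estimated at 8.2, between 7.2 and 9.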

Compound 3, negative logarithm of the antagonist equilibrium constant: 8.9
Beside the measured number, compound 3's estimate is 0.70 log units below it; the measured number falls inside the stated range.
By their numbers in this assay, from the lowest: compounds 1 and 2 (each within the scatter of the next); then compound 3.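

Among the compounds shown here, compound 2 and compound 1 showed only that the methoxy groups can be rearranged with no visible effect, whereas the amine end of the chain does respond to change in this assay. Putting 1-butylpiperidin-4-yl in place of 2-(piperidin-1-yl)ethyl on a saturated chain carbon, two bonds along the chain from a carbonyl carbon, gives a number 0.40 log units higher from compound 2 to compound 3 (beyond the scatter) and shows that this position accepts a group of 10 heavy atoms in place of one of 8 without any loss of potency. Nothing available here explains why this change raises the number.

This one step changes both the way the piperidine ring is attached and the butyl chain on its nitrogen, so a smaller 1-methylpiperidin-4-yl or a longer 1-hexylpiperidin-4-yl group would be needed to show how much depends on the length of that chain. Going by these compounds, it also remains open whether the same change would give a similar rise on the 3,4-dimethoxyphenyl compound, and whether a different ring at the amine end, such as a morpholine, would fare as well.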